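A few compounds are considered here, and "the series" means these few. Any claim that something is new, unique, unknown or untested is made for them only; others in the source may bear on it.

- compound 1 `O=C(CN[C@H]1CCN(S(=O)(=O)Cc2ccccc2)C1)N1CCN(Cc2cccc(F)c2)CC1` gives 13200 nM
- compound 2 `O=C(CN[C@H]1CCN(S(=O)(=O)Cc2ccccc2)C1)N1CCN(Cc2ccc(Cl)cc2Cl)CC1` gives 4300 nM

In a functional assay on K562 cells (Homo sapiens) for cytotoxicity, read by MTT assay, with a stated time of 48 h (a higher number here means a weaker inhibitor, a lower number a stronger inhibitor), compound 2 gives 4300 nM and holds the lower of the two numbers. Compound 3 `COc1ccc(CN2CCN(C(=O)CN[C@H]3CCN(S(=O)(=O)Cc4ccccc4)C3)CC2)cc1` is still unmeasured. Its difference from compound 2 is 4-methoxyphenyl in place of 2,4-dichlorophenyl on a saturated chain carbon bound to an amine nitrogen in a ring and amounts to 4-methoxyphenyl in place of 2,4-dichlorophenyl on a saturated chain carbon bound to an amine nitrogen in a ring. Within the data shown here, only one measured step bears on this place: a 3.1-fold lower number from compound 1 to compound 2 (0.49 log units; beyond the scatter) came with 2,4-dichlorophenyl entering in place of 3-fluorophenyl, a modest step beyond the scatter. Going by these compounds, with 2,4-dichlorophenyl leaving again, a step of similar modest size towards a higher number is expected in this assay on this single precedent, since 4-methoxyphenyl itself is untested here. The expected change is a 2.1-fold higher number from compound 2 to compound 3 (0.32 log units; beyond the scatter) and remains tentative. The estimate for compound 3 is 9000 nM with a range from 3500 nM to 23000 nM for now.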

Compound 3, half-maximal inhibitory concentration: 50900 nM
The estimate for compound 3 lay 5.7-fold (0.75 log units) below the measured number; the whole stated range lies below it.
By their numbers in this assay, from the lowest: compound 2; then compound 1; then compound 3.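

In this assay, among these compounds, the group on a saturated chain carbon bound to an amine nitrogen in a ring moves the number further than the one earlier step showed, with 4-methoxyphenyl replacing 2,4-dichlorophenyl giving a 12-fold higher number from compound 2 to compound 3 (1.07 log units; beyond the scatter) and 4-methoxyphenyl replacing 3-fluorophenyl giving a 3.9-fold higher number from compound 1 to compound 3 (0.59 log units; beyond the scatter). Both steps run towards a higher number, so 4-methoxyphenyl ranks behind both halogen-bearing groups, and compound 3 has the highest number of the three. Nothing on hand accounts for this order.

These compounds cannot separate a contribution of the methoxy group from the loss of the halogens, as each step changes both at once. Open too, going by these compounds, is how an unsubstituted phenyl, a 4-chlorophenyl or a 4-aminophenyl group would rank at this place.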